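Cytotoxicity notes: phenyl replacing benzyloxy on the carbonyl

The source may hold more compounds than are shown below. What is called first, only, known or untested is meant among the compounds shown, and "the series" means these compounds.

Three compounds of this series have been run in an ADME assay on Vero cells (Chlorocebus sabaeus) for cytotoxicity, read by resazurin assay, with a stated time of 3 days (on this read-out lower numbers stand for stronger inhibition and higher numbers for weaker inhibition), and none gives a number. Compound 2 `CN(C)c1cc2[nH]c(C3CCCCC3)nc2cc1NC(=O)OCc1ccccc1` gives > 100 ug/mL, which is a limit of the assay and not a measured value. Compound 1 `O=C(CCc1ccccc1)Nc1cc2nc(C3CCCCC3)[nH]c2cc1N1CCCC1` gives > 100 ug/mL, also a limit. Compound 3 `CCCN(CCC)c1cc2[nH]c(C3CCCCC3)nc2cc1NC(=O)OCc1ccccc1` gives > 100 ug/mL, again a limit. For the measured compounds named here, the only step between measured compounds that differ in one place is a step that the two limits leave unreadable from compound 2 to compound 3, and its size cannot be read because of the limit of > 100 ug/mL in this assay, at which 3 of the 3 values shown sit.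

Compound 4 `CN(C)c1cc2[nH]c(C3CCCCC3)nc2cc1NC(=O)c1ccccc1` is the next to be measured. It differs from compound 2 by phenyl in place of benzyloxy on a carbonyl carbon. Going by the values given here, no measured step touches the carbonyl substituent, and the one measured step, on the aromatic amine, is unreadable between two limits, so no direction can be taken from the data. The expectation for compound 4 in this assay is therefore no step beyond the scatter, and a step that the limit leaves unreadable from compound 2 to compound 4 is the expected step. Compound 4 is expected to give about 150 ug/mL, within 70 ug/mL to 300 ug/mL, most likely reported once more as a limit.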

Compound 4, half-maximal inhibitory concentration: > 100 ug/mL
Compound 4 was reported as a limit; the forecaster's own chance of this, stated with the estimate: 80%; the middle value lies beyond the limit too.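

No step can be read from compound 2 to compound 4 in this assay, because both stand at the same limit: the limit of > 100 ug/mL in this assay, at which 4 of the 4 values shown sit.

The compounds shown leave open at what concentration any of them turns cytotoxic, and whether phenyl in place of benzyloxy on the carbonyl carbon changes that concentration at all.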